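A few compounds are considered here, and "the series" means these few. Any claim that something is new, unique, unknown or untested is made for them only; others in the source may bear on it.

Three esters sharing one core have been measured in a functional assay on HBL-100 cells (Homo sapiens) for inhibition, read by sulforhodamine B assay, with a stated time of 48 h; on this read-out higher numbers stand for weaker inhibition of growth and lower numbers for stronger inhibition of growth. Compound 1 `CC(=O)OC/C(=C\c1ccccc1[N+](=O)[O-])C(=O)c1ccccc1` gives 26000 nM. Compound 2 `O=C(OC/C(=C\C1CCCCC1)C(=O)c1ccccc1)c1ccccc1` gives 23000 nM, and compound 3 `O=C(OC/C(=C\c1ccc(Cl)cc1Cl)C(=O)c1ccccc1)c1ccccc1` gives 3100 nM, the lowest of the three numbers, with compound 2 nearest and compound 1 furthest from it. Among the compounds with values here, the one single-place step measured so far, a 7.4-fold lower number from compound 2 to compound 3 (0.87 log units; beyond the scatter), shows that the group on that chain carbon matters. Compound 4 `O=C(OC/C(=C\c1ccccc1[N+](=O)[O-])C(=O)c1ccccc1)c1ccccc1` differs from compound 3 by 2-nitrophenyl in place of 2,4-dichlorophenyl on a double-bonded chain carbon bound to a double-bonded chain carbon. Compound 4 carries the same 2-nitrophenyl group as compound 1, whose number stands close to that of compound 2, so compound 4 is expected to give a higher number, an estimated step of a 4.8-fold higher number from compound 3 to compound 4 (0.68 log units; beyond the scatter). The estimate for compound 4 in this assay is 15000 nM, in a range from 5000 nM to 40000 nM.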

Compound 4, concentration for 50% growth inhibition: 3900 nM
Beside the measured number, compound 4's estimate is 3.8-fold (0.59 log units) above it; measured number outside the range, below it.
By their numbers in this assay, from the lowest: compounds 3 and 4 (each within the scatter of the next); then compounds 2 and 1 (each within the scatter of the next).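

In this assay the step of a 1.3-fold higher number from compound 3 to compound 4 (0.10 log units; within the scatter) puts 2-nitrophenyl and 2,4-dichlorophenyl on level terms at this chain carbon, and the step of a 5.9-fold lower number from compound 2 to compound 4 (0.77 log units; beyond the scatter) sets 2-nitrophenyl apart from cyclohexyl just as 2,4-dichlorophenyl was. The ester end matters too: with phenyl in place of methyl on the carbonyl carbon, the step is a 6.7-fold lower number from compound 1 to compound 4 (0.82 log units; beyond the scatter) and it brings a gain of its own. No available evidence explains these steps. Still open, going by these compounds, is whether plain phenyl or a pyridine ring at this chain carbon would match these two groups, and whether a longer chain on the carbonyl carbon would keep the gain seen with phenyl.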